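This account rests on a few compounds, and the source may have more. Where it says the series, first, only, none or still open, it means among the compounds named here.

Measured in a functional assay on HCT-116 cells (Homo sapiens), read by MTT assay, with a stated time of 72 h; on this read-out lower numbers stand for stronger inhibition and higher numbers for weaker inhibition:
- compound 1 `CNc1ncnc2c1c(-c1ccco1)cn2[C@@H]1O[C@H](CO)[C@@H](O)[C@H]1O`: 440 nM
- compound 2 `CNc1ncnc2c1c(-c1cccs1)cn2[C@@H]1O[C@H](CO)[C@@H](O)[C@H]1O`: > 20000 nM, a limit of the assay and not a number

Compound 2 stands at the limit of > 20000 nM in this assay, at which 1 of the 2 values shown sits, so its true position is not known. Compound 3 `CNc1ncnc2c1c(-c1ccsc1)cn2[C@@H]1O[C@H](CO)[C@@H](O)[C@H]1O` has the same atoms joined differently, with thiophen-3-yl in place of thiophen-2-yl on an aromatic carbon.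

Among the compounds with values here, only one measured step changes the group at this place: an at least 45-fold higher number from compound 1 to compound 2 (1.65 log units; beyond the scatter). It was large and lies beyond the scatter, which shows that swapping this ring can shift the result strongly in this assay. Within the data shown here, no measured step compares the two thiophenes, so the size of the new step is uncertain. Any visible change is expected to be toward a lower number, and a moderate one at that. The expected step is an at least 3.3-fold lower number from compound 2 to compound 3 (0.52 log units; beyond the scatter). For compound 3 the estimated value is 6000 nM, with an expected range from 1000 nM to 20000 nM.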

Compound 3, half-maximal inhibitory concentration: > 20000 nM
Compound 3: no number, only a limit; the forecaster's own chance of this, stated with the estimate: 45%; middle value at least 3.3-fold (0.52 log units) away from the limit.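

In this assay compound 3 gives > 20000 nM, a limit of the assay and not a number. Moving the attachment point of the thiophene ring therefore does not bring back the activity of the furan-2-yl compound, as replacing furan-2-yl with thiophen-3-yl gives an at least 45-fold higher number from compound 1 to compound 3 (1.65 log units; beyond the scatter). Neither thiophene gives a measured number here, so the difference between them cannot be read, because both values are limits: the limit of > 20000 nM in this assay, at which 2 of the 3 values shown sit.

On these data alone, how far compound 2 and compound 3 lie beyond the limit remains unknown. As far as these compounds go, it is also open whether the activity of compound 1 depends on the furan ring's oxygen, its point of attachment, or both, a question that furan-3-yl or pyrrol-2-yl at this position could help to answer.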